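A new aromatic group on compound 3

A few compounds are considered here, and "the series" means these few. Any claim that something is new, unique, unknown or untested is made for them only; others in the source may bear on it.

Measured in a functional assay on MCF7 cells (Homo sapiens) for cytotoxicity, read by sulforhodamine B assay; a lower number here means that less compound is tolerated, a higher number that more compound is tolerated
- compound 1 `CC1=CC[C@@H]([C@@](C)(O)CCCC(C)(C)NC(=S)N/N=C\c2ccccc2)CC1` gives 60400 nM
- compound 2 `CC1=CC[C@@H]([C@@](C)(O)CCCC(C)(C)NC(=S)N/N=C\c2ccc(O)cc2)CC1` gives 56400 nM
- compound 3 `CC1=CC[C@@H]([C@@](C)(O)CCCC(C)(C)NC(=S)N/N=C\c2ccc(N(C)C)cc2)CC1` gives > 100000 nM (a limit)

Compound 3 stands only at a limit of the assay, > 100000 nM, and has no number. Compound 4 `CC1=CC[C@@H]([C@@](C)(O)CCCC(C)(C)NC(=S)N/N=C\c2cccc([N+](=O)[O-])c2)CC1` is unmeasured and carries 3-nitrophenyl in place of 4-(dimethylamino)phenyl on a carbon with a double bond to nitrogen. For the measured compounds named here, three measured steps bear on this change, though none of them tests 3-nitrophenyl: a 1.1-fold lower number from compound 1 to compound 2 (0.03 log units; within the scatter), an at least 1.6-fold higher number from compound 1 to compound 3 (0.21 log units; that floor lies within the scatter) and an at least 1.7-fold higher number from compound 2 to compound 3 (0.24 log units; that floor lies within the scatter). With all of these inside the scatter, no step beyond the scatter is expected in this assay, although a lower number than the limit is the likelier direction. Compound 4 is expected to fall near compound 1 at 60400 nM. The expected step is an at least 1.8-fold lower number from compound 3 to compound 4 (0.25 log units; that floor lies within the scatter). Compound 4 is estimated at 55000 nM, with an expected range of 25000 nM to 100000 nM.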

Compound 4, concentration lethal to 50% of the cells: 47300 nM
For compound 4 the middle estimate is 1.2-fold (0.07 log units) above the measured one, within the range that was stated.
By their numbers in this assay, from the lowest: compounds 4, 2 and 1 (each within the scatter of the next). At a limit, above all of these: compound 3.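

In this assay, the change on this carbon with a double bond to nitrogen gives a step beyond the scatter, an at least 2.1-fold lower number from compound 3 to compound 4 (0.32 log units; beyond the scatter), though its size is only a floor. Compound 3 remains a limit of the assay and not a number: the limit of > 100000 nM in this assay, at which 1 of the 4 values shown sits. Nitro in place of hydrogen gives a 1.3-fold lower number from compound 1 to compound 4 (0.11 log units; within the scatter), and 3-nitrophenyl in place of 4-hydroxyphenyl gives a 1.2-fold lower number from compound 2 to compound 4 (0.08 log units; within the scatter), so 3-nitrophenyl stays with those two compounds rather than with compound 3.

Open, on these data alone, is whether a 3-(dimethylamino)phenyl or a 4-nitrophenyl group would stand with compound 3 or with compound 4, which would separate the group from its place on the ring.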